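Adding a second heptylcarbonyl group to compound 1

A few compounds are considered here, and "the series" means these few. Any claim that something is new, unique, unknown or untested is made for them only; others in the source may bear on it.

Measured in a functional assay on A549 cells (Homo sapiens) for antiproliferative activity, read by MTT assay, with a stated time of 72 h; on this read-out lower numbers stand for stronger inhibition and higher numbers for weaker inhibition:
Compound 1 `CCCCCCCC(=O)Oc1cc(C(=O)C2=C3OC(C)(C)[C@@H](CC=C(C)C)C[C@@]34C[C@@H](CC=C(C)C)C(C)(C)[C@H]3CCC(C)(C)O[C@]34OC2=O)ccc1O`: > 20000 nM, a limit.
Compound 2 `CC(C)=CC[C@H]1C[C@]23C[C@@H](CC=C(C)C)C(C)(C)[C@H]4CCC(C)(C)O[C@]42OC(=O)C(C(=O)c2ccc(O)c(O)c2)=C3OC1(C)C`: > 20000 nM, a limit.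
Compound 3 `CCCCCC(=O)Oc1cc(C(=O)C2=C3OC(C)(C)[C@@H](CC=C(C)C)C[C@@]34C[C@@H](CC=C(C)C)C(C)(C)[C@H]3CCC(C)(C)O[C@]34OC2=O)ccc1O`: 19500 nM.

Compound 1 has no exact number, only a limit of the assay. It stands at the limit of > 20000 nM in this assay, at which 2 of the 3 values shown sit.

Compound 4 `CCCCCCCC(=O)Oc1ccc(C(=O)C2=C3OC(C)(C)[C@@H](CC=C(C)C)C[C@@]34C[C@@H](CC=C(C)C)C(C)(C)[C@H]3CCC(C)(C)O[C@]34OC2=O)cc1OC(=O)CCCCCCC` differs from compound 1 in one place: heptylcarbonyl in place of hydrogen on an oxygen on an aromatic ring. Heptylcarbonyl takes the place of hydrogen on an oxygen on an aromatic ring, turning a hydroxy into (heptylcarbonyl)oxy.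

The nearest measured change of this kind adds pentylcarbonyl in place of hydrogen, and it gives an at least 1.0-fold lower number from compound 2 to compound 3 (0.01 log units; that floor lies within the scatter). The heptylcarbonyl change itself, run in reverse, gives a step that the two limits leave unreadable from compound 1 to compound 2. Shortening the chain gives an at least 1.0-fold lower number from compound 1 to compound 3 (0.01 log units; that floor lies within the scatter). None of these shows a change beyond the scatter in this assay, so no step beyond the scatter is expected, in either direction.

The expected outcome is a step that the limit leaves unreadable from compound 1 to compound 4, and this remains only an estimate. Another limit instead of a number is the likeliest report. Compound 4 is estimated at 22000 nM, with an expected range from 12000 nM to 40000 nM.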

Compound 4, half-maximal inhibitory concentration: > 20000 nM
Compound 4 ended at the assay's limit; the forecaster's own chance of this, stated with the estimate: 70%; the middle value lies beyond the limit too.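

Compound 4 gives > 20000 nM, which is a limit and not a number. Compound 1 also stands at a limit, and the step between compound 1 and compound 4 cannot be read. The compounds shown leave open whether a second heptylcarbonyl group changes the antiproliferative activity of compound 1 at all, in either direction.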